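The source may report more compounds than this note shows. Statements on the series, on what has been measured and on what is new or still open speak of the compounds shown alone.

Working notes on the series. Three measured compounds share one core and differ only in the group on the saturated chain carbon bound to the ether oxygen: compound 1 `Cc1cc(C)n(CCOC2CC(=O)Nc3c2c(C)nn3-c2ncnc3nc[nH]c23)n1` carries (3,5-dimethyl-1H-pyrazol-1-yl)methyl there, compound 2 `Cc1nn(-c2ncnc3nc[nH]c23)c2c1C(OCc1ccc(C(C)C)cc1)CC(=O)N2` carries 4-isopropylphenyl, and compound 3 `Cc1nn(-c2ncnc3nc[nH]c23)c2c1C(OCc1ccc(C#N)cc1)CC(=O)N2` carries 4-cyanophenyl. In a functional assay on HEK293 cells for agonist activity at G-protein coupled receptor 39 (Homo sapiens), read by scintillation proximity assay and inositol phosphate accumulation, with a stated time of 75 min, in the presence of a further agent that is not named here (on this read-out lower numbers stand for an effect already at smaller amounts and higher numbers for an effect only at larger amounts of compound), compound 1 gives 16 nM, compound 2 gives 5 nM and compound 3 gives 4 nM. The aryl groups set the two lower numbers: a 3.2-fold lower number from compound 1 to compound 2 (0.51 log units; beyond the scatter) and a 4.0-fold lower number from compound 1 to compound 3 (0.60 log units; beyond the scatter) are both beyond the scatter, whereas a 1.3-fold lower number from compound 2 to compound 3 (0.10 log units; within the scatter) is within it, so compound 3 and compound 2 cannot be separated on these data.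

Compound 4 `Cc1nn(-c2ncnc3nc[nH]c23)c2c1C(OCc1ccc(F)cc1)CC(=O)N2` differs from compound 3 in one place: fluoro in place of cyano on an aromatic carbon. Within the data shown here, the only measured step bearing on this exchange is the swap of the group on that same aromatic carbon, a 1.3-fold lower number from compound 2 to compound 3 (0.10 log units; within the scatter), which stayed within the scatter. The larger steps concern replacement of the whole (3,5-dimethyl-1H-pyrazol-1-yl)methyl and do not touch this position. For compound 4 in this assay the expected step is a 1.3-fold higher number from compound 3 to compound 4 (0.10 log units; within the scatter), not beyond the scatter. Compound 4 is estimated at 5 nM, range 2 nM to 12 nM.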

Compound 4, half-maximal effective concentration: 1 nM
Compound 4: middle estimate off by 5.0-fold (0.70 log units), on the high side; measured number below the stated range.
By their numbers in this assay, from the lowest: compound 4; then compounds 3 and 2 (each within the scatter of the next); then compound 1.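

In this assay the group on this aromatic carbon now matters: a 4.0-fold lower number from compound 3 to compound 4 (0.60 log units; beyond the scatter) and a 5.0-fold lower number from compound 2 to compound 4 (0.70 log units; beyond the scatter) both lie beyond the scatter, whereas the exchange between isopropyl and cyano at the same place had stayed within it. The aryl groups therefore do not act as one class against (3,5-dimethyl-1H-pyrazol-1-yl)methyl, since a 16-fold lower number from compound 1 to compound 4 (1.20 log units; beyond the scatter) is large while the steps from compound 1 to the other two aryl compounds are modest. Nothing at hand explains why fluoro gives the lowest number of the series.

As far as these compounds go, whether the low number is particular to fluoro or is shared by chloro, methoxy or an amine on this carbon remains open. Also open, from the compounds shown here alone, is whether fluoro keeps this number on another carbon of the ring, or whether a second fluoro changes it.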